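Acetoxymethyl in Place of Vinyl at the Chain Carbon

The source may hold more compounds than are shown below. What is called first, only, known or untested is meant among the compounds shown, and "the series" means these compounds.

Within the data shown here, in an assay on isolated protein (Oryctolagus cuniculus) with Thromboxane-A synthase (Homo sapiens) as the target, tested at 1 uM (on this read-out lower numbers stand for less inhibition and higher numbers for more inhibition at the one concentration tested (going by the name of the read-out)), compound 3 `C=CCn1nc(-c2cccnc2)c2ccccc2c1=O` gives 70%, the top of the three numbers measured so far. Nearest to it is compound 2 `Cn1nc(-c2cccnc2)c2ccccc2c1=O`, which in this assay gives 63%, so the two lie within the scatter of each other. Furthest away is compound 1 `Oc1nnc(-c2cccnc2)c2ccccc12`, which in this assay gives 26%, a gap to compound 3 that is beyond the scatter.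

Compound 4 `CC(=O)OCCn1nc(-c2cccnc2)c2ccccc2c1=O` differs from compound 3 in one place: acetoxymethyl in place of vinyl on a saturated chain carbon bound to an aromatic nitrogen. Among the measured compounds shown here, only one measured step touches this place, the one in which vinyl replaced hydrogen on the saturated chain carbon bound to the aromatic nitrogen, and it was small: a number 7 percentage points higher from compound 2 to compound 3 (within the scatter). For the measured compounds named here, no measured compound shows acetoxymethyl, or any oxygen-bearing chain, entering at this position, so the data give no direction for a larger movement. The step of a number 5 percentage points lower from compound 3 to compound 4 (within the scatter) is therefore expected to stay within the scatter. Compound 4 is estimated to give about 65% in this assay, with a range from 45% to 82%.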

Compound 4, a percentage reported as inhibition, at one concentration (the size of the read-out at that concentration, not a potency): 32%
The estimate for compound 4 lay 33 percentage points above the measured number; measured number outside the range, below it.
By their numbers in this assay, from the lowest: compounds 1 and 4 (each within the scatter of the next); then compounds 2 and 3 (each within the scatter of the next).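

In this assay, the place on the saturated chain carbon bound to an aromatic nitrogen proves far from indifferent: acetoxymethyl in place of vinyl gives a number 38 percentage points lower from compound 3 to compound 4 (beyond the scatter), and acetoxymethyl in place of hydrogen gives a number 31 percentage points lower from compound 2 to compound 4 (beyond the scatter). Until now this place had shown only the small step of a number 7 percentage points higher from compound 2 to compound 3 (within the scatter), so allyl and methyl on the nitrogen could not reveal that a group entering here can move the number beyond the scatter. No measurement at hand speaks to why the number falls.

The compounds shown leave open whether the drop follows the acetoxy ester itself or the length of the chain. They also leave open how a 2-hydroxyethyl chain, a propyl chain, a carboxylic acid or an amine would read at this place.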